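Methylsulfanyl to methylsulfonyl: an expected exposure step

The source may report more compounds than this note shows. Statements on the series, on what has been measured and on what is new or still open speak of the compounds shown alone.

Within the data shown here, in an ADME assay on the whole organism (plasma) for pharmacokinetics, with Rhesus monkey (Macaca mulatta) as the target, read by LC-MS, at a dose of 1 mg/kg by the oral route (on this read-out higher numbers stand for higher exposure at the dose given and lower numbers for lower exposure), compound 1 (`COc1ccc2nc(COc3ccc(CC(SC)C(N)=O)cc3)n(C)c2c1`) gives 16.9 ng.h/mL and stands lowest of the two numbers so far. Compound 2 (`COc1ccc2nc(COc3ccc(CC4SC(=O)N([C@@H]5O[C@H](C(=O)O)[C@@H](O)[C@H](O)[C@H]5O)C4=O)cc3)n(C)c2c1`) gives 892 ng.h/mL and lies well beyond the scatter above it. Compound 3 (`COc1ccc2nc(COc3ccc(CC(C(N)=O)S(C)(=O)=O)cc3)n(C)c2c1`) carries methylsulfonyl in place of methylsulfanyl on a saturated chain carbon bound to a carbonyl carbon and a saturated chain carbon. Among the measured compounds shown here, no measured step covers this change, so only a moderate, uncertain rise in this assay is expected. The estimated step is a 3.6-fold higher number from compound 1 to compound 3 (0.55 log units; beyond the scatter) and it remains loose. Compound 3 is estimated at 60 ng.h/mL with a range from 12 ng.h/mL to 300 ng.h/mL around it.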

Compound 3, area under the concentration-time curve: 27 ng.h/mL
Beside the measured number, compound 3's estimate is 2.2-fold (0.35 log units) above it; measured number inside the range.
By their numbers in this assay, from the lowest: compounds 1 and 3 (each within the scatter of the next); then compound 2.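

In this assay, methylsulfonyl in place of methylsulfanyl on a saturated chain carbon bound to a carbonyl carbon and a saturated chain carbon gives a 1.6-fold higher number from compound 1 to compound 3 (0.20 log units; within the scatter) and so lies within the usual scatter. At this position, the two sulfur groups cannot be told apart on this read-out. Nothing available bears on why this is so.

The compounds shown leave open how a carboxylic acid or an amine at this place would read. They also leave open whether a longer chain on the sulfur would separate from compound 1 and compound 3.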